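Changing the group on the aromatic nitrogen: toward compound 3

The compounds below may be only part of what the source reports. "The series", "measured", "known", "first", "only" and "open" are said of these compounds alone.

- compound 1 `Cc1ccc(-n2cc(COc3cccc4cnc(Nc5cccc(Cl)c5)nc34)nn2)c([N+](=O)[O-])c1` gives 21000 nM in the only assay run so far
- compound 2 `Clc1cccc(Nc2ncc3cccc(OCc4cn(Cc5c(Cl)cccc5Cl)nn4)c3n2)c1` gives 14000 nM in the same assay

Among the measured compounds shown here, in an ADME assay on cells (Fibroblast, Homo sapiens) for cytotoxicity, read by cell counting, with a stated time of 48 h (a higher number here means a weaker inhibitor, a lower number a stronger inhibitor), compound 2 stands at 14000 nM and compound 1 at 21000 nM as the only two measured values, and these lie within the scatter of each other. No order can be drawn between them.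

Compound 3 `Clc1cccc(Nc2ncc3cccc(OCc4cn(-c5ccc(Br)cc5)nn4)c3n2)c1` has not yet been measured. It carries 4-bromophenyl in place of 2,6-dichlorobenzyl on an aromatic nitrogen of a five-membered aromatic ring with 3 nitrogen, and the shared core stays the same.

For the measured compounds named here, the one measured step that changes the group on this aromatic nitrogen is a 1.5-fold lower number from compound 1 to compound 2 (0.18 log units; within the scatter) and it does not exceed the scatter. This single step is thin evidence, and it gives no direction. In this assay no step beyond the scatter is therefore expected, in either direction. The expected change is a 1.1-fold higher number from compound 2 to compound 3 (0.06 log units; within the scatter) as estimated here. For compound 3 the estimated value is 16000 nM with an expected range from 6000 nM to 40000 nM in this series.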

Compound 3, half-maximal inhibitory concentration: > 25000 nM
Compound 3: only a limit was reported (the forecaster's own chance of this, stated with the estimate: 10%); at least 1.5-fold (0.19 log units) between middle value and limit.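

In this assay compound 3 gives only a limit, not a number: the limit of > 25000 nM in this assay, at which 1 of the 3 values shown sits. Against the two groups read earlier on this aromatic nitrogen, 4-bromophenyl gives an at least 1.7-fold higher number from compound 2 to compound 3 (0.25 log units; that floor lies within the scatter) and an at least 1.1-fold higher number from compound 1 to compound 3 (0.07 log units; that floor lies within the scatter); both are floors, and neither establishes a separation. The earlier pair offered two numbers with no order between them, whereas this position now holds three groups with none shown apart beyond the scatter, and the gaps for 4-bromophenyl have a floor but no upper bound.

How far 4-bromophenyl lies from 2,6-dichlorobenzyl or from 4-methyl-2-nitrophenyl therefore stays unread, and a flat response at this position can be neither claimed nor excluded. A plain alkyl chain on this aromatic nitrogen, or a phenyl ring carrying a carboxylic acid or an amine, lies outside the compounds shown, so the response of this assay to such groups remains open.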